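This account rests on a few compounds, and the source may have more. Where it says the series, first, only, none or still open, it means among the compounds named here.

Measured compounds:
- compound 1 `CC1CCN(C2CCN(S(=O)(=O)c3cccc4ccccc34)CC2)CC1` — in a functional assay on DLD-1 cells (Homo sapiens) for antiproliferative activity, read by CellTiter-Glo, with a stated time of 72 h (on this read-out higher numbers stand for weaker inhibition and lower numbers for stronger inhibition), compound 1 gives 0.65 nM
- compound 2 `COc1cc(C)ccc1S(=O)(=O)N1CCC(N2CCC(C)CC2)CC1` — in this assay compound 2 gives only a limit, > 5000 nM

Among the measured compounds shown here, compound 1 holds the only actual number among the values shown; the one other entry is a limit rather than a measurement. Compound 2 sits at the limit of > 5000 nM in this assay, at which 1 of the 2 values shown sits, so it reports no number of its own. For the measured compounds named here, no step between two measured compounds is available.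

Compound 3 `CC(=O)Nc1ccc(S(=O)(=O)N2CCC(N3CCC(C)CC3)CC2)c2ccccc12` differs from compound 1 in one place: acetamido in place of hydrogen on an aromatic carbon. The change sits on the fused ring system of compound 1, which compound 2 lacks, and compound 2 returns only a limit, so that ring system appears to carry much of the activity. The step is expected to be a modest loss, a 7.7-fold higher number from compound 1 to compound 3 (0.89 log units; beyond the scatter), since a new group is added to that same ring. Compound 3 is therefore estimated at 5 nM, within a range from 0.8 nM to 40 nM.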

Compound 3, half-maximal inhibitory concentration: 1100 nM
Compound 3: middle estimate off by 220-fold (2.34 log units), on the low side; the whole stated range lies below it.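

Acetamido in place of hydrogen on an aromatic carbon, para to a large group, proves costly: in this assay this single change gives a 1700-fold higher number from compound 1 to compound 3 (3.23 log units; beyond the scatter). Among the compounds shown here, it is the first step that can be read here, and it shows that this carbon of the fused system responds strongly to what it carries, since one added group takes away most of the activity of compound 1 while the rest of the structure stays the same. Nothing measured here gives a reason for this loss.

From the compounds shown here alone, it remains open whether the loss belongs to acetamido itself or to any group on this carbon, which a fluorine atom, a methyl group or a free amine there would separate. Also open, going by these compounds, is how the other aromatic carbons of that ring respond to the same group.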